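Mouse microsome half-life: amine substituent change on shared core

A few compounds are considered here, and "the series" means these few. Any claim that something is new, unique, unknown or untested is made for them only; others in the source may bear on it.

compound 1 `CC(C)N1C(=O)C(=O)N=C1/N=C(\NOCc1ccccc1)Nc1ccc(Cl)c(Cl)c1`: > 1 h
compound 2 `CC(C)N1C(=O)C(=O)N=C1/N=C(/Nc1ccc(Cl)c(Cl)c1)NC(C)(C)C`: > 1 h
compound 3 `CC(C)N1C(=O)C(=O)N=C1/N=C(\NCCN1CCCC1)Nc1ccc(Cl)c(Cl)c1`: not yet measured

In an in vitro ADME assay on microsomes from liver (Mus musculus) for metabolic stability, read by LC-MS (on this read-out lower numbers stand for a shorter-lived compound and higher numbers for a longer-lived compound), compound 1 gives > 1 h, which is a limit of the assay and not a number. In this assay compound 2 gives > 1 h, likewise a limit. The step that the two limits leave unreadable from compound 1 to compound 2 is therefore unreadable, both values sitting at the limit of > 1 h in this assay, at which 2 of the 2 values shown sit. Compound 3 differs from compound 1 by 2-(pyrrolidin-1-yl)ethyl in place of benzyloxy on an amine nitrogen. Among the compounds with values here, no measured step bears on this change, and compound 1 itself stands only at a limit. The step that the limit leaves unreadable from compound 1 to compound 3 is accordingly expected without a readable direction. Compound 3 is expected at 1.5 h, within 0.5 h to 4 h.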

Compound 3, half-life: > 1 h
Compound 3: a limit, no number (the forecaster's own chance of this, stated with the estimate: 60%); the middle value is on the limit's open side.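

No step among compound 1, compound 2 and compound 3 can be read in this assay, since all three values are limits of the assay: the limit of > 1 h in this assay, at which 3 of the 3 values shown sit.

Still open, on these data alone, is whether the substituent on the amine nitrogen alters half-life at all, and by how much.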